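Fluorination of the phenoxy ring in a Jurkat cell series

A few compounds are considered here, and "the series" means these few. Any claim that something is new, unique, unknown or untested is made for them only; others in the source may bear on it.

Compound 1 `CC(C)[C@H](NC(=O)COc1cccc2ccccc12)C(=O)N[C@@H](CC(=O)O)C(=O)COc1c(F)cccc1F` is the reference of this short series. In a functional assay on Jurkat cells (Homo sapiens) (on this read-out higher numbers stand for weaker inhibition and lower numbers for stronger inhibition), compound 1 gives 2040 nM. Compound 2 `CC(C)[C@H](NC(=O)COc1cccc2ccccc12)C(=O)N[C@@H](CC(=O)O)C(=O)COc1c(F)cc(F)cc1F` differs from it by fluoro in place of hydrogen on an aromatic carbon and in this assay compound 2 gives 6840 nM, a step of a 3.4-fold higher number from compound 1 to compound 2 (0.53 log units; beyond the scatter). Compound 3 `CC(C)[C@H](NC(=O)COc1cccc2ccccc12)C(=O)N[C@@H](CC(=O)O)C(=O)COc1c(F)c(F)cc(F)c1F` carries a different core; the difference is 2,3,5,6-tetrafluorophenyl in place of 2,6-difluorophenyl on an oxygen on a saturated carbon. In this assay compound 3 gives 4500 nM, with a 2.2-fold higher number from compound 1 to compound 3 (0.34 log units; beyond the scatter) and a 1.5-fold lower number from compound 2 to compound 3 (0.18 log units; within the scatter). Compound 4 `CC(C)[C@H](NC(=O)COc1cccc2ccccc12)C(=O)N[C@@H](CC(=O)O)C(=O)COc1c(F)c(F)c(F)c(F)c1F` is not yet measured; it differs from compound 3 by fluoro in place of hydrogen on an aromatic carbon. Within the data shown here, this is the same kind of change as the one from compound 1 to compound 2, but the surroundings differ: in compound 3 the aromatic carbon is ortho to two fluoro groups as well as meta to two fluoro groups and para to a large group, whereas in compound 1 it is meta to two fluoro groups and para to a large group. Among the measured compounds shown here, the only measured example of this kind of change is a 3.4-fold higher number from compound 1 to compound 2 (0.53 log units; beyond the scatter), and no step among the three measured compounds is large, so a modest weakening is expected for compound 4, a 1.8-fold higher number from compound 3 to compound 4 (0.25 log units; within the scatter). Compound 4 is therefore estimated at 8000 nM in this assay, with a range from 4000 nM to 18000 nM.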

Compound 4, half-maximal inhibitory concentration: 3050 nM
For compound 4 the middle estimate is 2.6-fold (0.42 log units) above the measured one; measured number below the stated range.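

In this assay, fluoro in place of hydrogen on an aromatic carbon does not carry over from one core to the other as a fixed step: the same change on two cores in this assay, a 3.4-fold higher number (0.53 log units; beyond the scatter) from compound 1 to compound 2 and a 1.5-fold lower number (0.17 log units; within the scatter) from compound 3 to compound 4, 4.9-fold (0.69 log units) apart, beyond the scatter of two such steps

On the core of compound 3 the change stays within the scatter, with a 1.5-fold lower number from compound 3 to compound 4 (0.17 log units; within the scatter), and the pentafluorophenyl compound also stays within the scatter of the difluorophenyl reference, with a 1.5-fold higher number from compound 1 to compound 4 (0.17 log units; within the scatter), while the comparison with the 2,4,6-trifluorophenyl compound lies beyond it, with a 2.2-fold lower number from compound 2 to compound 4 (0.35 log units; beyond the scatter). Among these compounds, with only one pair on each core, this shows that the step differed between these two settings, but it does not show which feature of the surroundings accounts for the difference, and it gives no rule for a third core.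

From the compounds shown here alone, it remains open how a chloro or methoxy group at the same place on the ring would compare with fluoro. Going by these compounds, it is also open whether the same contrast would appear if the naphthyloxy-bearing end of the molecule carried a different group.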